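The compounds below may be only part of what the source reports. "The series", "measured", "known", "first", "only" and "open" are said of these compounds alone.

Measured in a functional assay on MLM cells (Homo sapiens) for cytotoxicity, using microsomes; a higher number here means that more compound is needed for the effect, a lower number that less compound is needed:
- compound 1 `COc1cc(/C=C/c2ccc(C(C)C)cc2)cc(OC)c1OC`: > 25 uM (a limit)
- compound 2 `COc1cc(/C=C\c2ccc(C(C)C)cc2)cc(OC)c1OC`: 7 uM
- compound 3 `COC(=O)C(Cc1cc(OC)c(OC)c(OC)c1)c1ccc(OC)cc1`: > 25 uM (a limit)

Among the measured compounds shown here, compound 2 gives the only actual number at 7 uM. The results for compound 1 and compound 3 are limits of the assay. The next compound to read is compound 4 `CCCOc1ccc(/C=C\c2cc(OC)c(OC)c(OC)c2)cc1`, which keeps the double bond drawn Z as in compound 2. The change is propoxy in place of isopropyl on an aromatic carbon, with propoxy in place of isopropyl on an aromatic carbon, para to a large group.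

For the measured compounds named here, the one measured step is an at least 3.5-fold lower number from compound 1 to compound 2 (0.55 log units; beyond the scatter). It rests on (the fact that compounds 1 and 2 differ only in the configuration as drawn), and its size is open-ended given (the limit of > 25 uM in this assay, at which 2 of the 3 values shown sit). That step leaves the isopropyl in place, so it bears on the double bond that compound 4 retains but gives no size for the exchange of groups. Going by the values given here, no measured step covers that exchange, so neither direction is favoured with any confidence.

Compound 4 is expected to give a number rather than a limit, as it shares the Z double bond of compound 2 at 7 uM. The expected change is a 1.1-fold higher number from compound 2 to compound 4 (0.06 log units; within the scatter), which means no step beyond the scatter is anticipated. In this assay, the estimate for compound 4 is 8 uM, with an expected range of 2 uM to 25 uM.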

Compound 4, concentration for half-maximal effect: 6.5 uM
For compound 4 the middle estimate is 1.2-fold (0.09 log units) above the measured one, within the range that was stated.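

In this assay, propoxy in place of isopropyl on an aromatic carbon, para to a large group, gives a 1.1-fold lower number from compound 2 to compound 4 (0.03 log units; within the scatter), the first measured size for an exchange at this position. The earlier compounds shown here showed a step only for the configuration of the double bond; with that double bond drawn Z in both compounds, the group para to a large group now has a reading of its own, and compound 4 gives 6.5 uM, a number and not a limit. Propoxy, unlike isopropyl, carries an oxygen and a hydrogen-bond acceptor, yet the two compounds stand within the scatter of each other, and nothing measured here gives a reason for this reading.

Still open, on these data alone, is how this position responds to a group of another kind, such as an amine, a carboxylic acid or a longer chain like hexyloxy on the shared core. Also open, as far as these compounds go, is the same exchange on the double bond drawn E: the isopropyl compound of that form, compound 1, gives > 25 uM, which is a limit of the assay.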